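Adding a methoxy group to compound 2

A few compounds are considered here, and "the series" means these few. Any claim that something is new, unique, unknown or untested is made for them only; others in the source may bear on it.

In a functional assay on A549 cells (Homo sapiens) for antiproliferative activity, read by MTT assay, with a stated time of 48 h (on this read-out higher numbers stand for weaker inhibition and lower numbers for stronger inhibition), compound 1 (`O=C(/C=C\Nc1ccc(F)cc1)c1cn(-c2ccccc2)nc1-c1ccccc1`) gives 4670 nM and compound 2 (`O=C(/C=C\Nc1ccc(O)cc1)c1cn(-c2ccccc2)nc1-c1ccccc1`) gives 3210 nM. These two values lie within the scatter of each other, so compound 2 cannot be separated from compound 1 on these numbers. Compound 3 (`COc1ccc(-c2nn(-c3ccccc3)cc2C(=O)/C=C\Nc2ccc(O)cc2)cc1`) differs from compound 2 by phenyl to 4-methoxyphenyl, with methoxy in place of hydrogen on an aromatic carbon. Going by the values given here, the only measured step, a 1.5-fold lower number from compound 1 to compound 2 (0.16 log units; within the scatter), exchanges fluoro for hydroxy elsewhere in the molecule and stays within the scatter. Among the compounds with values here, it bears only indirectly on the new change, and no measured pair tests a methoxy group. No step beyond the scatter is therefore expected in this assay, in either direction. The expected change is a 1.1-fold lower number from compound 2 to compound 3 (0.06 log units; within the scatter), which is an estimate only. Compound 3 is estimated at 2800 nM, with an expected range from 900 nM to 8500 nM.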

Compound 3, half-maximal inhibitory concentration: 2770 nM
The estimate for compound 3 lay 1.0-fold (0.00 log units) above the measured number, and the stated range covers the measured number.
By their numbers in this assay, from the lowest: compounds 3, 2 and 1 (each within the scatter of the next).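

Replacing hydrogen with methoxy on this aromatic carbon, which turns phenyl into 4-methoxyphenyl, gives a 1.2-fold lower number from compound 2 to compound 3 (0.06 log units; within the scatter) in this assay. Going by these compounds alone, this is the first measured change at this position, since the earlier pair differed elsewhere in the molecule, and it shows that methoxy can be carried here with no shift that stands clear of the scatter in this assay. No measurement shown here offers an explanation for this result.

From the compounds shown here alone, whether this position would respond to a different kind of group, such as an amine, a carboxylic acid or a longer alkoxy chain, remains open. Going by these compounds, it is also open whether methoxy would give a similar result at another place on the shared core.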